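Fluoro and methyl changes on a quinazolinone-like amide series

The source may report more compounds than this note shows. Statements on the series, on what has been measured and on what is new or still open speak of the compounds shown alone.

Measured so far, in an ADME assay on microsomes from liver (Homo sapiens) for metabolic stability; a lower number here means slower removal, a higher number faster removal of the compound:
- compound 1 `Cc1ccc([C@H](C)NC(=O)Cn2nnc3ccccc3c2=O)cc1` gives < 9.9 mL/min/kg, which is a limit of the assay rather than a number.
- compound 2 `Cc1ccc([C@H](C)NC(=O)Cn2nnc3ccccc3c2=O)c(F)c1` gives 28 mL/min/kg.
- compound 3 `Cc1ccc([C@H](C)NC(=O)Cn2nnc3ccc(C)cc3c2=O)cc1` gives 179 mL/min/kg.

Compound 2 differs from compound 1 by fluoro in place of hydrogen on an aromatic carbon, and that change made an at least 2.8-fold higher number from compound 1 to compound 2 (0.45 log units; beyond the scatter). Compound 3 differs from compound 1 by methyl in place of hydrogen on an aromatic carbon, and that change made an at least 18-fold higher number from compound 1 to compound 3 (1.25 log units; beyond the scatter), leaving compound 3 with the highest number among the measured compounds.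

Compound 4 `Cc1ccc([C@H](C)NC(=O)Cn2nnc3c(F)cc(C)cc3c2=O)cc1` is not yet measured. It differs from compound 3 by fluoro in place of hydrogen on an aromatic carbon. Among the compounds with values here, this is the same kind of change as the one from compound 1 to compound 2, though the surroundings differ: in compound 4 the fluoro enters a ring that is part of a fused or bridged system of two rings, ortho to a fused ring and meta to a fused ring, while in compound 2 it enters a ring that is ortho to a large group.

Because the earlier fluoro step made an at least 2.8-fold higher number from compound 1 to compound 2 (0.45 log units; beyond the scatter), a similar step is expected here, a 1.6-fold higher number from compound 3 to compound 4 (0.19 log units; within the scatter). Compound 4 is therefore estimated at 280 mL/min/kg in this assay, with a plausible range from 130 mL/min/kg to 600 mL/min/kg.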

Compound 4, clearance: 85 mL/min/kg
Estimate against measurement, compound 4: 3.3-fold (0.52 log units) above, outside the stated range (below it).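

In this assay, fluoro in place of hydrogen on an aromatic carbon gave a 2.1-fold lower number from compound 3 to compound 4 (0.32 log units; beyond the scatter), so in this series the change did not keep its direction from one core to the other: the same change on two cores in this assay, an at least 2.8-fold higher number (0.45 log units; beyond the scatter) from compound 1 to compound 2 and a 2.1-fold lower number (0.32 log units; beyond the scatter) from compound 3 to compound 4, at least 5.9-fold (0.77 log units) apart, beyond the scatter of two such steps. Compound 1 holds a limit of the assay rather than a number, and the earlier step starts from that limit: the limit of < 9.9 mL/min/kg in this assay, at which 1 of the 4 values shown sits. The pair does not show why the direction differs, since the fluoro does not enter the same ring in the two steps, and two steps cannot separate the role of the core from the role of the place where the fluoro sits.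

Still open, on these data alone, is whether fluoro at the carbon used in compound 4 would also lower the number on the core of compound 1, which lacks the methyl group, and whether fluoro at the carbon used in compound 2 would raise it on the core of compound 3. Also open, as far as these compounds go, is how chloro, methoxy or an amine at either carbon would compare with fluoro.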